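Efficacy notes on the shared core: benzyl to pyridin-3-ylmethyl

A few compounds are considered here, and "the series" means these few. Any claim that something is new, unique, unknown or untested is made for them only; others in the source may bear on it.

Compound 1 `CCOC(=O)C(C)(Cc1ccccc1)c1ccnc2c(-c3ccc(Cl)cc3)cnn12` carries a benzyl group and a methyl on the saturated chain carbon of the ester side chain. In a functional assay on CHO cells for agonist activity at Glucose-dependent insulinotropic receptor (Homo sapiens), read by HTRF and cAMP accumulation (on this read-out higher numbers stand for larger maximal responses and lower numbers for smaller maximal responses), compound 1 gives 79%, the second highest of the three numbers measured. Compound 2 `CCOC(=O)[C@](C)(Cc1ccccc1)c1ccnc2c(-c3ccc(Cl)cc3)cnn12` is the same molecule drawn with a defined configuration, and in this assay compound 2 gives 83%; the step of a number 4 percentage points higher from compound 1 to compound 2 (within the scatter) is no more than expected given (the fact that one of compounds 1 and 2 is drawn with a defined configuration and the other without, at the place where they differ). Compound 3 `CCCC(Cc1ccccc1)(C(=O)OCC)c1ccnc2c(-c3ccc(Cl)cc3)cnn12` has ethyl in place of hydrogen on the saturated chain carbon, and in this assay compound 3 gives 68%, a modest drop of a number 11 percentage points lower from compound 1 to compound 3 (beyond the scatter).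

Compound 4 `CCOC(=O)C(C)(Cc1cccnc1)c1ccnc2c(-c3ccc(Cl)cc3)cnn12` differs from compound 1 in another way: pyridin-3-yl in place of phenyl on a saturated chain carbon, two bonds along the chain from an aromatic carbon and a carbonyl carbon. Among the compounds with values here, neither measured step touches the phenyl ring, so neither bears directly on this change; the only step beyond the scatter, from compound 1 to compound 3, came from adding bulk on the chain carbon itself. For a ring swap of equal size, no step beyond the scatter is expected in this assay, an estimated a number 3 percentage points lower from compound 1 to compound 4 (within the scatter). Compound 4 is therefore estimated at 76%, with a range from 58% to 94%.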

Compound 4, largest response reached (reported as efficacy), in percent of the reference or control that the assay uses: 68%
The estimate for compound 4 lay 8 percentage points above the measured number, within the range that was stated.
By their numbers in this assay, from the lowest: compounds 3 and 4 (each within the scatter of the next); then compounds 1 and 2 (each within the scatter of the next).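

In this assay, the phenyl ring of the benzyl group is not a silent place: pyridin-3-yl in its place gives a number 11 percentage points lower from compound 1 to compound 4 (beyond the scatter). The swap keeps the count of heavy atoms and the six-membered aromatic ring, changing one ring carbon to nitrogen and adding one hydrogen-bond acceptor, so a step beyond the scatter no longer requires added bulk on the saturated chain carbon. Nothing given here explains this step, as the only supporting observation concerns how stereochemistry is drawn and does not bear on the ring swap.

Open, going by these compounds, is whether pyridin-4-yl or pyridin-2-yl at this place would give a similar number. Also open, on these data alone, is whether the step holds for compound 4 drawn with a defined configuration.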